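From Hydroxycyclohexyl to Methylcarbamoylcyclohexyl

The source may hold more compounds than are shown below. What is called first, only, known or untested is meant among the compounds shown, and "the series" means these compounds.

Measured in an assay on isolated protein for inhibition of protein kinase C delta type (Homo sapiens), read by TR-FRET, with a stated time of 2 h; on this read-out lower numbers stand for stronger inhibition and higher numbers for weaker inhibition:
- compound 1, `N#Cc1cnc(NCc2cnccc2C(F)(F)F)cc1N[C@H]1CC[C@H](O)CC1`, gives 6500 nM.
- compound 2, `N#Cc1cnc(NCc2ccccc2C(F)(F)F)cc1N[C@H]1CC[C@H](O)CC1`, gives > 10000 nM, which is a limit of this assay and not a number.
- compound 3, `N#Cc1cnc(NCc2ccccc2C(F)(F)F)cc1N[C@H]1C[C@@H](C(N)=O)C1`, gives 4200 nM.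
- compound 4, `CNC(=O)[C@H]1CC[C@@H](Nc2cc(NCc3cnccc3C(F)(F)F)ncc2C#N)CC1`, is not yet measured.

Of the two numbers, compound 1 stands highest; its nearest neighbour is compound 3, whose value lies within the scatter of that of compound 1, so no order can be drawn between the two. Compound 2 sits at the limit of > 10000 nM in this assay, at which 1 of the 3 values shown sits.

Compound 4 differs from compound 1 in one place: 4-(methylcarbamoyl)cyclohexyl in place of 4-hydroxycyclohexyl on a nitrogen on an aromatic ring. For the measured compounds named here, one measured step bears on this change. an at least 2.3-fold lower number from compound 2 to compound 3 (0.37 log units; beyond the scatter). There a 3-carbamoylcyclobutyl group also replaced the 4-hydroxycyclohexyl group on the same nitrogen, and the number fell; because compound 2 rests on (the limit of > 10000 nM in this assay, at which 1 of the 3 values shown sits), the size of that fall is known only as a lower bound. The change into compound 4 keeps a six-membered non-aromatic ring of carbon only and brings in the 4-(methylcarbamoyl)cyclohexyl group, so a step of similar kind, downward and at least modest, is expected in this assay. Compound 4 is therefore expected to give 3000 nM, within 1000 nM to 9000 nM. That estimate means an expected step of a 2.2-fold lower number from compound 1 to compound 4 (0.34 log units; beyond the scatter).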

Compound 4, half-maximal inhibitory concentration: 1600 nM
Estimate against measurement, compound 4: 1.9-fold (0.27 log units) above; low and high end bracket the measured number.
By their numbers in this assay, from the lowest: compound 4; then compounds 3 and 1 (each within the scatter of the next). At a limit, above all of these: compound 2.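

In this assay, for the compounds shown here, the step of a 4.1-fold lower number from compound 1 to compound 4 (0.61 log units; beyond the scatter) is the first one at this nitrogen read between two numbers, and it shows that 4-(methylcarbamoyl)cyclohexyl in place of 4-hydroxycyclohexyl gives a lower number than the hydroxy compound. The one earlier replacement on this nitrogen started from compound 2, and its size is known only as a lower bound because the value of compound 2 is a limit and not a number: the limit of > 10000 nM in this assay, at which 1 of the 4 values shown sits. That earlier change also swapped the six-membered ring for a cyclobutyl ring, whereas compound 1 and compound 4 both carry one six-membered non-aromatic ring of carbon only, so a lower number at this position does not depend on leaving that ring.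

The compounds shown leave open whether the methyl on the amide nitrogen matters, and how a plain carbamoyl, a carboxylic acid or an amine on the same cyclohexyl ring would compare with compound 4. They also leave open whether the same replacement would lower the number on the core of compound 2, and they do not tell why the number falls here.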